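The source may hold more compounds than are shown below. What is called first, only, known or untested is meant among the compounds shown, and "the series" means these compounds.

Compound 1 `CC(C)C(=O)N1CC2CC(C1)N2`: 86%
Compound 2 `O=C(C1CCCC1)N1CC2CC(C1)N2`: 48%
Compound 3 `O=C(C1CC=CC1)N1CC2CC(C1)N2`: 93%

Three compounds share one core and differ only in the group on the carbonyl carbon. In an assay on SH-EP1 cells for agonist activity at Neuronal acetylcholine receptor; alpha4/beta2 (Homo sapiens), read by FLIPR and calcium flux (on this read-out lower numbers stand for smaller maximal responses and higher numbers for larger maximal responses), compound 1 gives 86%, the second highest of the three numbers; compound 3 lies within the usual scatter of it, while compound 2 lies well below, beyond the scatter. Compound 4 `C[C@H]1C[C@H]1C(=O)N1CC2CC(C1)N2` has not yet been measured. It differs from compound 1 in one place: 2-methylcyclopropyl in place of isopropyl on a carbonyl carbon. Going by the values given here, no measured pair shows this exact change. Compound 2 gives 48% and compound 3 gives 93%, so the two ring-bearing compounds point in different directions. Compound 4 is expected to give 78%, likely between 55% and 98%. The expected step of a number 8 percentage points lower from compound 1 to compound 4 (within the scatter) is small, downward if at all.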

Compound 4, largest response reached (Emax), in percent of the reference or control that the assay uses: 87%
Compound 4: the middle estimate sits 9 percentage points below what was measured; the range from low to high includes it.
By their numbers in this assay, from the lowest: compound 2; then compounds 1, 4 and 3 (each within the scatter of the next).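

In this assay, the step is a number 1 percentage points higher from compound 1 to compound 4 (within the scatter) when 2-methylcyclopropyl takes the place of isopropyl on the carbonyl carbon. A ring at this place therefore does not always go with a lower response, although compound 2, at 48%, still goes against that reading. No measurement shown explains this difference between the ring-bearing groups.

Still open, from the compounds shown here alone, is how an amine, a carboxylic acid or a longer chain would behave on this carbonyl carbon. The mirror-image form of the 2-methylcyclopropyl group also remains an open case.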